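This account rests on a few compounds, and the source may have more. Where it says the series, first, only, none or still open, it means among the compounds named here.

In a functional assay on SK-OV-3 cells (Homo sapiens) for cytotoxicity, read by sulforhodamine B assay, with a stated time of 48 h (a lower number here means a stronger inhibitor of growth, a higher number a weaker inhibitor of growth), compound 1 `ClCc1ccc(Cn2cnc3c(Cl)ncnc32)cc1` gives 13800 nM, the second highest of the three numbers in hand. Compound 2 `ClCc1cccc(Cn2cnc3c(Cl)ncnc32)c1` gives 10500 nM, and compound 3 `ClCc1ccccc1Cn1cnc2ncnc(Cl)c21` gives 26900 nM; both of these fall within the scatter of the number for compound 1, so the three are not separated by this assay. Compound 4 `ClCc1ccc(Cn2cnc3c(Cl)nc(Cl)nc32)cc1` is not yet measured. Compound 4 differs from compound 1 by chloro in place of hydrogen on an aromatic carbon, on the shared core, between two ring nitrogen atoms. Going by the values given here, no step between measured compounds bears on this change, so its size is open; a step of modest size in either direction, or none beyond the scatter, is expected. Compound 4 is expected at 9000 nM, with a range of 3000 nM to 27000 nM, meaning a 1.5-fold lower number from compound 1 to compound 4 (0.19 log units; within the scatter) is expected.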

Compound 4, concentration for total growth inhibition: 29500 nM
Compound 4: middle estimate off by 3.3-fold (0.52 log units), on the low side; measured number outside the range, above it.
By their numbers in this assay, from the lowest: compounds 2, 1, 3 and 4 (each within the scatter of the next, the first and the last beyond it).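

Chloro in place of hydrogen on an aromatic carbon of the shared core, between two ring nitrogen atoms, gives a 2.1-fold higher number from compound 1 to compound 4 (0.33 log units; beyond the scatter) in this assay and moves toward a weaker inhibitor of growth. This position therefore responds to substitution, whereas compound 1, compound 2 and compound 3 alone showed nothing about it. Nothing in hand accounts for the direction of this step.

The compounds shown carry only hydrogen or chloro here, so the effect of an amine or a methoxy group at this position stays open. As far as these compounds go, whether chloro gives a similar step on compound 2 or compound 3 also stays open.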